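The source may report more compounds than this note shows. Statements on the series, on what has been measured and on what is new or still open speak of the compounds shown alone.

Measured in a functional assay on SU-DHL-6 cells (Homo sapiens) for antiproliferative activity, read by MTT assay; on this read-out higher numbers stand for weaker inhibition and lower numbers for stronger inhibition:
- compound 1 `COc1ncc(-c2ccc3ncnc(N[C@H]4CCCN(C(=O)C5CCN(C)CC5)C4)c3c2)cc1C#N`: 420 nM
- compound 2 `COc1ncc(-c2ccc3ncnc(N[C@H]4CCCN(C(=O)CCl)C4)c3c2)cc1C#N`: 380 nM

Compound 2, at 380 nM, cannot be separated from compound 1, at 420 nM. Within the data shown here, the a 1.1-fold lower number from compound 1 to compound 2 (0.04 log units; within the scatter) is the only measured step, and it lies within the scatter.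

The next compound is compound 3 `COc1ncc(-c2ccc3ncnc(N[C@H]4CCCN(C(=O)c5cccnc5)C4)c3c2)cc1C#N`, which carries pyridin-3-yl in place of chloromethyl on a carbonyl carbon. In words, this is pyridin-3-yl in place of chloromethyl on a carbonyl carbon.

Among the measured compounds shown here, the one measured step bears on this change. It is a swap on the same carbonyl carbon: a 1.1-fold lower number from compound 1 to compound 2 (0.04 log units; within the scatter) exchanged 1-methylpiperidin-4-yl for chloromethyl and left this assay within the scatter. For the measured compounds named here, that is a single step, and no compound with an aromatic ring on this carbonyl has been measured, so the evidence is thin and the range has to stay wide. No shift beyond the scatter is expected, in either direction. The expected step is a 1.1-fold higher number from compound 2 to compound 3 (0.02 log units; within the scatter). For compound 3 the estimated value is 400 nM, with an expected range of 130 nM to 1200 nM.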

Compound 3, half-maximal inhibitory concentration: 120 nM
Compound 3: middle estimate off by 3.3-fold (0.52 log units), on the high side; the whole stated range lies above it.
By their numbers in this assay, from the lowest: compound 3; then compounds 2 and 1 (each within the scatter of the next).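

In this assay, the group on the carbonyl carbon whose other neighbour is the amide-type nitrogen in a ring now makes a difference: pyridin-3-yl in place of chloromethyl gives a 3.2-fold lower number from compound 2 to compound 3 (0.50 log units; beyond the scatter), and pyridin-3-yl in place of 1-methylpiperidin-4-yl gives a 3.5-fold lower number from compound 1 to compound 3 (0.54 log units; beyond the scatter), both modest steps. The earlier exchange of 1-methylpiperidin-4-yl for chloromethyl, a 1.1-fold lower number from compound 1 to compound 2 (0.04 log units; within the scatter), had suggested little sensitivity here, but the two new steps show that this place can respond, with compound 3 alone standing apart from a pair that cannot be separated. No measurement at hand says what lies behind this separation.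

With only one aromatic group on this carbonyl, the compounds shown cannot tell whether the stronger inhibition goes with the six-membered aromatic ring itself or with its ring nitrogen, a question that phenyl, pyridin-2-yl or pyridin-4-yl on the same carbonyl carbon would address. Also open, from the compounds shown here alone, is how a longer chain carrying the same ring, such as pyridin-3-ylmethyl, would read in this assay.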